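The source may hold more compounds than are shown below. What is called first, only, known or untested is meant among the compounds shown, and "the series" means these compounds.

This account follows a small set of compounds on a shared core, tested in a toxicity assay on cells (Erythrocyte, Mus musculus) for activation, read by spectrophotometry and hemolysis, with a stated time of 30 min; a higher number here means that more compound is needed for the effect, a lower number that less compound is needed. In this assay, compound 1 `O=[N+]([O-])c1ccc(O)c(/C=N/Nc2nc3ccccc3s2)c1` gives > 200 ug/mL, which is a limit of the assay and not a number. In this assay, compound 2 `COc1cc(/C=N/Nc2nc3ccccc3s2)ccc1O` gives > 200 ug/mL, which is also a limit and not a number. Both compounds thus sit at one reading: the limit of > 200 ug/mL in this assay, at which 2 of the 2 values shown sit. Going by the values given here, no actual half-maximal concentration is available for compound 2, and no step between measured compounds is available either.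

Compound 3 `Oc1ccc(/C=N/Nc2nc3ccccc3s2)cc1O` is reached from compound 2 by one structural change, methoxy to hydroxy: hydrogen in place of methyl on an oxygen on an aromatic ring. In words, hydrogen stands in place of methyl on an oxygen on an aromatic ring. No step beyond the scatter is expected in this assay, and no direction is favoured. The expected step is a number no higher from compound 2 to compound 3 (the limit leaves the size open), an estimate that stays within the scatter. Compound 3 is estimated at about 200 ug/mL, with an expected range of 100 ug/mL to 400 ug/mL. The assay may well report only a limit for it.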

Compound 3, half-maximal effective concentration: > 200 ug/mL
Compound 3: a limit, no number (the forecaster's own chance of this, stated with the estimate: 80%); the middle value sits exactly at the limit.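

In this assay compound 3 gives > 200 ug/mL, which is a limit of the assay and not a number. Going by these compounds alone, no step between compound 2 and compound 3 can be read. The compounds shown leave open where any half-maximal concentration lies and whether methoxy to hydroxy changes it at all, with all readings at one value: the limit of > 200 ug/mL in this assay, at which 3 of the 3 values shown sit.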